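The compounds below may be only part of what the source reports. "The series", "measured", "known", "first", "only" and "open" are said of these compounds alone.

Measured compounds:
- compound 1 `c1ccc(C2=NN(C3=NC(c4ccccc4)CS3)C(c3cccc4ccccc34)C2)cc1`: 14300 nM
- compound 2 `c1ccc(C2=NN(C3=NC(c4ccccc4)CS3)C(c3ccc4ccccc4c3)C2)cc1`: 9620 nM
- compound 3 `Cc1ccc(C2=NN(C3=NC(=O)CS3)C(c3ccc4ccccc4c3)C2)cc1C`: 6020 nM

In a functional assay on BGC-823 cells (Homo sapiens) for inhibition, read by CCK-8 assay, with a stated time of 48 h (on this read-out higher numbers stand for weaker inhibition and lower numbers for stronger inhibition), compound 1 gives the highest of the three numbers. Among the measured compounds shown here, the only single-point step measured, a 1.5-fold lower number from compound 1 to compound 2 (0.17 log units; within the scatter), lies within the scatter. Compound 3 stands furthest from compound 1, and that gap is beyond the scatter, but the two differ in more than one place, so it is not a single step.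

Compound 4 `Clc1ccc(C2=NN(C3=NC(c4ccccc4)CS3)C(c3cccc4ccccc34)C2)cc1` differs from compound 1 by chloro in place of hydrogen on an aromatic carbon. For the measured compounds named here, no measured step concerns a substituent on this phenyl; the one step measured touches a different part of the core. There is therefore no basis for expecting a shift beyond the scatter, and the expected step is a 1.3-fold lower number from compound 1 to compound 4 (0.11 log units; within the scatter). For compound 4 the estimate in this assay is 11000 nM, with a range of 4500 nM to 27000 nM.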

Compound 4, half-maximal inhibitory concentration: 19600 nM
Compound 4: the middle estimate sits 1.8-fold (0.25 log units) below what was measured; the range from low to high includes it.
By their numbers in this assay, from the lowest: compounds 3, 2, 1 and 4 (each within the scatter of the next, the first and the last beyond it).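

Among the compounds shown here, this is the only measured single step on this phenyl: chloro in place of hydrogen, para to a large group, gives a 1.4-fold higher number from compound 1 to compound 4 (0.14 log units; within the scatter) in this assay. On the core of compound 1, phenyl to 4-chlorophenyl therefore stays within the scatter, as does the naphthalen-2-yl for naphthalen-1-yl step. No measurement at hand accounts for this result.

The compounds shown leave open whether an amine, a carboxylic acid or a methoxy group at this position would move the number beyond the scatter. Also open, going by these compounds, is whether chloro gives a similar step on compound 2.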